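A few compounds are considered here, and "the series" means these few. Any claim that something is new, unique, unknown or untested is made for them only; others in the source may bear on it.

The shared core of these compounds was tested in a functional assay on MDA-MB-231 cells (Homo sapiens) for cytotoxicity, read by sulforhodamine B assay, with a stated time of 72 h; a lower number here means a stronger inhibitor of growth, a higher number a weaker inhibitor of growth. Compound 1, `O=C(Nc1cc(C(F)(F)F)cc(C(F)(F)F)c1)C1CCc2ccccc2N1C(=O)c1ccccc1Cl`, gives 5250 nM, the lowest of the two plain numbers reported. Compound 2, `O=C(Nc1ccccc1O)C1CCc2ccccc2N1C(=O)c1cccc(Cl)c1`, gives 10600 nM in this assay, a gap from compound 1 that lies beyond the usual scatter. Compound 3, `O=C(Nc1ccc(O)cc1)C1CCc2ccccc2N1`, in this assay reaches only a limit of the measurement, > 100000 nM, not a number.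

Compound 4, `O=C(Nc1cc(C(F)(F)F)cc(C(F)(F)F)c1)C1CCc2ccccc2N1`, has not yet been measured. It differs from compound 1 in a single place: hydrogen in place of (2-chlorophenyl)carbonyl on a nitrogen on an aromatic ring in a ring. Compound 3 carries only a hydrogen on that same nitrogen, and it is the weakest result in the set because it sits at the limit of > 100000 nM in this assay, at which 1 of the 3 values shown sits. A large move toward a weaker inhibitor is therefore expected for the step of an 11-fold higher number from compound 1 to compound 4 (1.06 log units; beyond the scatter). Compound 4 is estimated to give 60000 nM in this assay, with a likely range from 20000 nM to 150000 nM, and there is a real chance that it, too, is reported only as a limit rather than a number.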

Compound 4, concentration for 50% growth inhibition: 8270 nM
Compound 4: middle estimate off by 7.3-fold (0.86 log units), on the high side; the measured number lies below the stated range.
By their numbers in this assay, from the lowest: compounds 1, 4 and 2 (each within the scatter of the next, the first and the last beyond it). At a limit, above all of these: compound 3.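

In this assay, exchanging (2-chlorophenyl)carbonyl for hydrogen on this nitrogen makes no difference that can be told apart from the scatter: a 1.6-fold higher number from compound 1 to compound 4 (0.20 log units; within the scatter). With two trifluoromethyl groups on the other aromatic ring, the (2-chlorophenyl)carbonyl is therefore not required for a plain number here, and hydrogen on this nitrogen does not by itself lead to a limit. Compound 3 also carries hydrogen on this nitrogen, and its result is a limit, not a number: the limit of > 100000 nM in this assay, at which 1 of the 4 values shown sits.

On these data alone, it remains open whether the ring with the two trifluoromethyl groups is what separates compound 4 from compound 3. As far as these compounds go, it is also open how a small acetyl group, a methyl group or a longer alkyl chain on this nitrogen would compare with hydrogen.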